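Swapping the aryl on the carbonyl carbon of compound 3

This account rests on a few compounds, and the source may have more. Where it says the series, first, only, none or still open, it means among the compounds named here.

Compound 3 `COc1cc(-c2cc(/C=C/C(=O)c3ccc(Cl)c(Cl)c3)[nH]n2)cc(OC)c1OC` has been tested in a functional assay on 786-0 cells (Homo sapiens) for cytotoxicity, read by sulforhodamine B assay, with a stated time of 48 h, tested at 1 uM (a higher number here means a weaker effect of the compound at the concentration tested, a lower number a stronger effect), and gives 91%. For the measured compounds named here, of the three compounds measured so far this is the highest number, but the two others lie close: compound 1 `COc1ccc(-c2cc(/C=C/C(=O)c3ccc(N)cc3)[nH]n2)cc1` gives 88% in this assay, and compound 2 `COc1cc(-c2cc(/C=C/C(=O)c3ccc(N)cc3)[nH]n2)cc(OC)c1OC` gives 81%, and both gaps to compound 3 are within the scatter, so the three cannot be separated on these numbers.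

Compound 4 `COc1ccc(C(=O)/C=C/c2cc(-c3cc(OC)c(OC)c(OC)c3)n[nH]2)cc1` is the next member of the series and differs from compound 3 in one place: 4-methoxyphenyl in place of 3,4-dichlorophenyl on a carbonyl carbon.

One earlier step concerns the same position, the aryl on the carbonyl carbon: a number 10 percentage points higher from compound 2 to compound 3 (within the scatter). Going by the values given here, that step, from an amino-bearing phenyl to a chlorine-bearing phenyl, stayed within the scatter, and every value recorded in this assay so far sits in the same weak band. Among the compounds with values here, there is no recorded step involving a 4-methoxyphenyl at this position, so the estimate rests on the flat picture across compound 1, compound 2 and compound 3.

Compound 4 is therefore expected to give about 87% in this assay, with a likely range of 74% to 98%, meaning an expected step of a number 4 percentage points lower from compound 3 to compound 4 (within the scatter), no change beyond the scatter.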

Compound 4, a percentage reported as activity, at one concentration (the size of the read-out at that concentration, not a potency): 94%
For compound 4 the middle estimate is 7 percentage points below the measured one; the measured number falls inside the stated range.
By their numbers in this assay, from the lowest: compounds 2, 1, 3 and 4 (each within the scatter of the next, the first and the last beyond it).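

With 4-methoxyphenyl in place of 3,4-dichlorophenyl on the carbonyl carbon, this assay shows a number 3 percentage points higher from compound 3 to compound 4 (within the scatter), so a third aryl at this position, carrying an oxygen and no chlorine, still gives no change that can be read. For the compounds shown here, the same position also yields the first step to clear the scatter: with methoxy in place of amino on an aromatic carbon, there is a number 13 percentage points higher from compound 2 to compound 4 (beyond the scatter), a modest step that leaves the amino-bearing compound 2 with the stronger effect of the pair, although the step from compound 2 to compound 3 stays within the scatter. Nothing available explains why this single pair separates while the other aryl change does not.

Whether the amino group itself matters rests on this one pair, and the compounds shown do not say whether a hydroxy or a dimethylamino group on that aromatic carbon would follow compound 2 or compound 4. They also leave open whether any aryl at this position, such as a pyridine ring or a phenyl bearing a carboxylic acid, can move the read-out far from this narrow band.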